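Replacing pyrazin-2-yl in compound 3 with 1,2-thiazol-3-yl

The source may report more compounds than this note shows. Statements on the series, on what has been measured and on what is new or still open speak of the compounds shown alone.

Values so far in an ADME assay on the whole organism (Rattus norvegicus) for pharmacokinetics, using cassette dosing, at a dose of 1 mg/kg by the oral route; on this read-out lower numbers stand for lower oral bioavailability and higher numbers for higher oral bioavailability:
- compound 1 `CC(C)Oc1ccc(/N=c2\[nH]c(=O)n(C[C@@H](O)CO)c(=O)n2Cc2ccc(Cl)cc2)cc1Cl` gives 63%
- compound 2 `C[C@@H](Cn1c(=O)[nH]/c(=N\c2ccc(Oc3cncc(F)c3)cc2)n(Cc2ccc(Cl)cc2)c1=O)C(=O)O` gives 74.3%
- compound 3 `C[C@@H](Cn1c(=O)[nH]/c(=N\c2ccc(Oc3cnccn3)cc2)n(Cc2ccc(Cl)cc2)c1=O)C(=O)O` gives 56.5%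

Compound 3 at 56.5% and compound 1 at 63% lie within the scatter of each other. Of the two other compounds, only compound 2 stands clear of compound 3 on these numbers.

Compound 4 `C[C@@H](Cn1c(=O)[nH]/c(=N\c2ccc(Oc3ccsn3)cc2)n(Cc2ccc(Cl)cc2)c1=O)C(=O)O` differs from compound 3 in one group: 1,2-thiazol-3-yl in place of pyrazin-2-yl on an oxygen on an aromatic ring. For the measured compounds named here, the only measured step at this place is a number 17.8 percentage points lower from compound 2 to compound 3 (beyond the scatter) and there pyrazin-2-yl took the place of 5-fluoropyridin-3-yl. That step shows that the group on this oxygen can move the read-out by a modest amount. Going by the values given here, compound 1 differs from compound 3 in more than one place and offers no single-change step. Among the compounds with values here, no measured compound carries a five-membered ring on this oxygen, so the data give no firm direction. The expected step is a number 3.5 percentage points higher from compound 3 to compound 4 (within the scatter) in this assay and it is not expected to go beyond the scatter. Compound 4 is estimated at 60% with an expected range from 40% to 80% as the working figure.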

Compound 4, oral bioavailability: 87.6%
Compound 4: the middle estimate sits 27.6 percentage points below what was measured, and the stated range ends below it.
By their numbers in this assay, from the lowest: compounds 3 and 1 (each within the scatter of the next); then compound 2; then compound 4.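

In this assay, the group on this oxygen has a larger reach than the earlier step showed: 1,2-thiazol-3-yl in place of pyrazin-2-yl gives a number 31.1 percentage points higher from compound 3 to compound 4 (beyond the scatter) on the same core, and in place of 5-fluoropyridin-3-yl it gives a number 13.3 percentage points higher from compound 2 to compound 4 (beyond the scatter) on that core as well. Compound 4 therefore stands clear of both compounds that differ from it only at this oxygen, so the one five-membered aromatic ring shown here ranks above the two other groups at this place, and the order in this small set runs from pyrazin-2-yl through 5-fluoropyridin-3-yl to 1,2-thiazol-3-yl. No measurement at hand accounts for these steps.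

With a single five-membered ring in the set, the ring size and the sulfur atom cannot be told apart, and 1,2-oxazol-3-yl, with an oxygen where 1,2-thiazol-3-yl has its sulfur, would separate the two. Also open, as far as these compounds go, is whether 1,2-thiazol-3-yl keeps this standing when the carboxylic acid chain shared by compound 2, compound 3 and compound 4 gives way to an amide or a longer chain.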